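A few compounds are considered here, and "the series" means these few. Any claim that something is new, unique, unknown or untested is made for them only; others in the source may bear on it.

Series values in a functional assay on DU-145 cells (Homo sapiens) for antiproliferative activity, read by MTT assay, with a stated time of 72 h; a lower number here means a stronger inhibitor, a higher number a weaker inhibitor:

- Compound 1 `COc1cccc(N(C)S(=O)(=O)C2CC3OC2C(c2ccc(NC(=O)CCCCCCC(=O)O)cc2)=C3c2ccc(O)cc2)c1`: 62200 nM
- Compound 2 `CN(c1ccccc1Cl)S(=O)(=O)C1CC2OC1C(c1ccc(NC(=O)CCCCCCC(=O)O)cc1)=C2c1ccc(O)cc1`: 73500 nM
- Compound 3 `CN(c1cccc2ccccc12)S(=O)(=O)C1CC2OC1C(c1ccc(NC(=O)CCCCCCC(=O)O)cc1)=C2c1ccc(O)cc1`: 70900 nM

Among the compounds with values here, compound 3 stands level with the other two compounds in this assay, as no step separates it from either beyond the scatter. Within the data shown here, the steps that bear on the next change are exchanges of the aromatic group on the sulfonamide nitrogen: a 1.2-fold higher number from compound 1 to compound 2 (0.07 log units; within the scatter), a 1.1-fold higher number from compound 1 to compound 3 (0.06 log units; within the scatter) and a 1.0-fold lower number from compound 2 to compound 3 (0.02 log units; within the scatter). All three are small.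

Compound 4 `CCN(c1ccc(C)cc1)S(=O)(=O)C1CC2OC1C(c1ccc(NC(=O)CCCCCCC(=O)O)cc1)=C2c1ccc(O)cc1` carries ethyl(4-methylphenyl)amino in place of methyl(naphthalen-1-yl)amino on a sulfonyl sulfur. Among the measured compounds shown here, no measured compound has this group, and no measured step isolates the exchange of methyl for ethyl, so the evidence is indirect. With only the aromatic exchanges to go on, no shift beyond the scatter is expected in this assay. The expected step is a 1.0-fold lower number from compound 3 to compound 4 (0.02 log units; within the scatter). For compound 4 the estimated value is 68000 nM, with an expected range of 38000 nM to 115000 nM.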

Compound 4, half-maximal inhibitory concentration: 53500 nM
For compound 4 the middle estimate is 1.3-fold (0.10 log units) above the measured one; the measured number falls inside the stated range.
By their numbers in this assay, from the lowest: compounds 4, 1, 3 and 2 (each within the scatter of the next).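

In this assay, the change on the sulfonyl sulfur now reaches beyond the aromatic group: ethyl(4-methylphenyl)amino alters the alkyl group on the nitrogen as well, yet all three new steps stay within the scatter, namely a 1.3-fold lower number from compound 3 to compound 4 (0.12 log units; within the scatter), a 1.4-fold lower number from compound 2 to compound 4 (0.14 log units; within the scatter) and a 1.2-fold lower number from compound 1 to compound 4 (0.07 log units; within the scatter). Against methyl(naphthalen-1-yl)amino, the entering group has one six-membered aromatic ring instead of two, and this difference also leaves the read-out unresolved from the earlier compounds. No measurement at hand offers an explanation for this flat response.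

The ethyl and 4-methylphenyl parts change together in compound 4, so their separate contributions cannot be read. On these data alone, it remains open whether morpholin-4-yl on the sulfonyl sulfur, a saturated amine with no aromatic ring, would give a step beyond the scatter.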